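Hydroxyphenyl position change carried from one core to another

A few compounds are considered here, and "the series" means these few. Any claim that something is new, unique, unknown or untested is made for them only; others in the source may bear on it.

Measured compounds:
Compound 1, `Oc1ccc(-c2cc(-c3cccc(F)c3)cc(-c3ccccc3O)n2)cc1`. In a functional assay on HeLa cells (Homo sapiens) for inhibition (on this read-out higher numbers stand for weaker inhibition and lower numbers for stronger inhibition), compound 1 gives > 50000 nM, which is a limit of the assay and not a number.
Compound 2, `Oc1ccc(-c2cc(-c3cccc(F)c3)cc(-c3cccc(O)c3)n2)cc1`. In this assay compound 2 gives 14200 nM.
Compound 3, `Oc1ccccc1-c1cc(-c2ccccc2C(F)(F)F)cc(-c2ccccc2O)n1`. In this assay compound 3 gives 5800 nM.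

The change from compound 1 to compound 2 is 3-hydroxyphenyl in place of 2-hydroxyphenyl on an aromatic carbon. In this assay it gives an at least 3.5-fold lower number from compound 1 to compound 2 (0.54 log units; beyond the scatter). Only a lower bound on its size is known because of the limit of > 50000 nM in this assay, at which 1 of the 3 values shown sits. Of the two numbered values, compound 3 has the lower one, and its gap to compound 2 is beyond the scatter.

Compound 4, `Oc1cccc(-c2cc(-c3ccccc3C(F)(F)F)cc(-c3ccccc3O)n2)c1`, is not yet measured. The change from compound 3 to compound 4 is 3-hydroxyphenyl in place of 2-hydroxyphenyl on an aromatic carbon. It is the same kind of change as from compound 1 to compound 2, but the surroundings differ: in compound 1 the place is meta to a 3-fluorophenyl group and meta to a 4-hydroxyphenyl group, in compound 3 it is meta to a 2-(trifluoromethyl)phenyl group and meta to a 2-hydroxyphenyl group. How the two cores of compound 1 and compound 3 differ is not broken down here.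

On the strength of an at least 3.5-fold lower number from compound 1 to compound 2 (0.54 log units; beyond the scatter), the step from compound 3 to compound 4 is expected to be a 2.9-fold lower number from compound 3 to compound 4 (0.46 log units; beyond the scatter), with wider uncertainty since the earlier step is only a bound and the surroundings are not the same. In this assay compound 4 is expected to give 2000 nM, estimated between 700 nM and 6000 nM.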

Compound 4, half-maximal inhibitory concentration: 16800 nM
Estimate against measurement, compound 4: 8.4-fold (0.92 log units) below; the whole stated range lies below it.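

In this assay, 3-hydroxyphenyl in place of 2-hydroxyphenyl next to the ring nitrogen gives a 2.9-fold higher number from compound 3 to compound 4 (0.46 log units; beyond the scatter), the opposite direction to the step on the core of compound 1, so in this series the change does not carry from one core to the other: the same change on two cores in this assay, an at least 3.5-fold lower number (0.54 log units; beyond the scatter) from compound 1 to compound 2 and a 2.9-fold higher number (0.46 log units; beyond the scatter) from compound 3 to compound 4, at least 10-fold (1.00 log units) apart, beyond the scatter of two such steps

The value of compound 1 is a limit of the assay and not a number, so the size of the earlier step is known only as a bound: the limit of > 50000 nM in this assay, at which 1 of the 4 values shown sits.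

The two cores differ in more than one place, 3-fluorophenyl against 2-(trifluoromethyl)phenyl and 4-hydroxyphenyl against 2-hydroxyphenyl, and the two steps do not show which of these differences goes with the reversal.

As far as these compounds go, it remains open whether exchanging 3-fluorophenyl for 2-(trifluoromethyl)phenyl alone, with the other groups held constant, would turn the step around. Also open, from the compounds shown here alone, is how either core responds at this place to a 4-hydroxyphenyl group, or to a phenyl ring carrying a methoxy group, an amine or a carboxylic acid in place of the hydroxyl.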